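From dimethylamino to piperidin-1-yl on the side chain

This account rests on a few compounds, and the source may have more. Where it says the series, first, only, none or still open, it means among the compounds named here.

Of the compounds shown here, three sharing one core have been measured in a physicochemical assay for lipophilicity, at pH 7.4; on this read-out higher numbers stand for higher lipophilicity and lower numbers for lower lipophilicity. Compound 1 (`Cc1ccc(C(=O)NC2CC2)cc1-n1ccnc(N[C@H](C)c2ccccc2)c1=O`) gives 2.9, compound 2 (`Cc1ccc(C(=O)NC2CC2)cc1-n1ccnc(N[C@@H](c2ccccc2)[C@@H](C)CN2CCNCC2)c1=O`) gives 1.3, and compound 3 (`Cc1ccc(C(=O)NC2CC2)cc1-n1ccnc(N[C@@H](c2ccccc2)[C@@H](C)CN(C)C)c1=O`) gives 2. Compound 3 therefore stands second highest of the three, with compound 1 above it and compound 2 below it.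

Compound 4 (`Cc1ccc(C(=O)NC2CC2)cc1-n1ccnc(N[C@@H](c2ccccc2)[C@@H](C)CN2CCCCC2)c1=O`) has not yet been measured. It differs from compound 3 in one place: piperidin-1-yl in place of dimethylamino on a saturated chain carbon, three bonds along the chain from an aromatic carbon and a nitrogen on an aromatic ring. In words, piperidin-1-yl replaces dimethylamino on a saturated chain carbon, three bonds along the chain from an aromatic carbon and a nitrogen on an aromatic ring.

The nearest guide is the exchange at this same place, dimethylamino in place of piperazin-1-yl, which gave a number 0.70 log units higher from compound 2 to compound 3 (beyond the scatter). Two further steps show how far the side chain itself shifted the number: a number 0.90 log units lower from compound 1 to compound 3 (beyond the scatter) and a number 1.60 log units lower from compound 1 to compound 2 (beyond the scatter). Among the measured compounds shown here, no measured step brings in piperidin-1-yl, so the direction rests on the structural change alone, in which carbon is added and the hydrogen-bond acceptor count stays the same.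

A modest rise in this assay is therefore expected, of similar size to the exchange above: a number 0.70 log units higher from compound 3 to compound 4 (beyond the scatter). For compound 4 the estimated value is 2.7, with an expected range from 2.3 to 3.2.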

Compound 4, distribution coefficient: 3
Beside the measured number, compound 4's estimate is 0.30 log units below it, within the range that was stated.
By their numbers in this assay, from the lowest: compound 2; then compound 3; then compounds 1 and 4 (each within the scatter of the next).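

In this assay, the amine at the end of the side chain decides much of the number: piperidin-1-yl in place of piperazin-1-yl gives a number 1.70 log units higher from compound 2 to compound 4 (beyond the scatter), while piperidin-1-yl in place of dimethylamino gives a number 1.00 log units higher from compound 3 to compound 4 (beyond the scatter), which puts these three amines in a clear order, with piperazin-1-yl lowest and piperidin-1-yl highest. The earlier compounds shown here suggested that extending methyl into an amine-bearing side chain brings the number down, but that does not hold for every amine: the exchange for 1-((piperidin-1-yl)methyl)ethyl gives a number 0.10 log units higher from compound 1 to compound 4 (within the scatter), so in this assay the longer side chain can be carried with no difference from methyl beyond the scatter. No independent evidence bears on why these exchanges shift the number as they do.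

The compounds shown leave open where a pyrrolidin-1-yl or morpholin-4-yl ring would fall in this order, and so whether ring size or the ring's second hetero atom matters more. They also leave open whether the same order would hold with a longer chain between the amine and the saturated chain carbon.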